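A few compounds are considered here, and "the series" means these few. Any claim that something is new, unique, unknown or untested is made for them only; others in the source may bear on it.

Measured so far in a functional assay on the whole organism with Rattus norvegicus as the target; on this read-out higher numbers stand for an effect only at larger amounts of compound and lower numbers for an effect already at smaller amounts:
compound 1 `CCOC(=O)C(=O)Nc1ccc(N(C)C)cc1C#N` gives 2.4 mg/kg
compound 2 `CCOC(=O)C(=O)Nc1cccc(N(C)CC)c1C#N` gives 0.5 mg/kg

Compound 2 holds the lower of the two numbers; compound 1 sits higher by a gap beyond the usual scatter. Compound 3 `CCOC(=O)C(=O)Nc1cccc(F)c1C#N` differs from compound 2 by fluoro in place of ethyl(methyl)amino on an aromatic carbon. Among the measured compounds shown here, no pair of measured compounds covers this change, so its size cannot be read from the series itself. A shift toward higher numbers in this assay is expected, of moderate size and with wide uncertainty. For compound 3 the expected value is 2 mg/kg, with a range from 0.6 mg/kg to 7 mg/kg. The step this estimate implies is a 4.0-fold higher number from compound 2 to compound 3 (0.60 log units; beyond the scatter).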

Compound 3, dose for half-maximal effect: 59 mg/kg
For compound 3 the middle estimate is 30-fold (1.47 log units) below the measured one, and the stated range ends below it.
By their numbers in this assay, from the lowest: compound 2; then compound 1; then compound 3.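

In this assay, the swap of ethyl(methyl)amino for fluoro on the aromatic carbon ortho to a cyano group gives a 120-fold higher number from compound 2 to compound 3 (2.07 log units; beyond the scatter), a large step. The dose needed at this position therefore depends strongly on the group it carries, and the smaller fluoro is far from equivalent here. Nothing available explains the size of this step.

As far as these compounds go, it remains open whether the nitrogen or its ethyl and methyl chains account for the difference. A methylamino group, a methoxy group or plain hydrogen on this carbon would help separate these.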